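This account rests on a few compounds, and the source may have more. Where it says the series, first, only, none or still open, it means among the compounds named here.

Measured compounds:
- compound 1 `COc1cccc(-n2cc3nc(-c4cccnc4C)n(C[C@H]4CCCN(CC5CCCC5)C4)c(=O)c3n2)c1` gives 12 nM
- compound 2 `Cc1ncccc1-c1nc2cn(-c3ccc(C#N)cc3)nc2c(=O)n1CC1CCCN(C2COC2)C1` gives 4000 nM
- compound 3 `Cc1ccccc1-c1nc2cn(-c3cccc(C#N)c3)nc2c(=O)n1CC1CCCN(C(C)C)C1` gives 32 nM

All three values come from an assay on HEK293 cells for displacement of a labelled ligand from growth hormone secretagogue receptor type 1 (Homo sapiens), with a stated time of 60 min; a higher number here means a weaker inhibitor, a lower number a stronger inhibitor. Compound 1 has the lowest number of the three. Its nearest neighbour is compound 3, whose number is higher by a margin that lies beyond the usual scatter; compound 2 lies much further off, again well beyond the scatter. Going by the values given here, compounds 2 and 3 differ from compound 1 in more than one place, so no single step between any two measured compounds can be read from these numbers, and nothing here separates the effect of one change from another.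

Compound 4 `COc1cccc(-n2cc3nc(-c4cccnc4C)n(C[C@H]4CCCN(CC5CCCCC5)C4)c(=O)c3n2)c1` has not yet been measured in this assay. It differs from compound 1 in one place only: cyclohexyl in place of cyclopentyl on a saturated chain carbon bound to an amine nitrogen in a ring. Among the compounds with values here, no pair of measured compounds shows what such a change does, so the expectation for compound 4 rests on compound 1 alone.

The change from cyclopentylmethyl to cyclohexylmethyl is small, and the expected step of no change at the digits printed from compound 1 to compound 4 (within the scatter) is none beyond the scatter. For compound 4 the estimate in this assay is 12 nM, with a range from 4 nM to 40 nM.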

Compound 4, half-maximal inhibitory concentration: 200 nM
Compound 4: the middle estimate sits 17-fold (1.22 log units) below what was measured, outside the stated range (above it).
By their numbers in this assay, from the lowest: compound 1; then compound 3; then compound 4; then compound 2.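

In this assay, the place on a saturated chain carbon bound to an amine nitrogen in a ring proves sensitive to the size of the carbocycle: cyclohexyl in place of cyclopentyl gives a 17-fold higher number from compound 1 to compound 4 (1.22 log units; beyond the scatter), a large step beyond the scatter. Going by these compounds alone, this is the first single-place step, and it shows that cyclopentylmethyl and cyclohexylmethyl cannot be treated as interchangeable here, which the earlier compounds, differing in more than one place, could not reveal. No measurement at hand bears on why this step is so large.

On these data alone, whether cyclobutyl, an open chain such as isobutyl, or a six-membered ring carrying an oxygen, such as tetrahydropyranyl, would stay close to compound 1 at 12 nM remains open. With only this one step available, the compounds shown also leave open whether the same change has a step of similar size when the groups elsewhere on the shared core are different.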